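Working notes: from compound 2 to compound 3

The source may hold more compounds than are shown below. What is called first, only, known or untested is meant among the compounds shown, and "the series" means these compounds.

- compound 1 `O=C1NC(O)C(F)=CN1[C@H]1C=C[C@@H](CO)O1`: 32200 nM
- compound 2 `Nc1nc(=O)n([C@H]2C=C[C@@H](CO)O2)cc1Br`: 91600 nM

Among the compounds with values here, in a functional assay on PBM cells (Homo sapiens) for cytotoxicity (on this read-out lower numbers stand for stronger inhibition and higher numbers for weaker inhibition), compound 2 gives 91600 nM, the higher of the two numbers so far. Compound 1 gives 32200 nM, and the gap between the two lies beyond the usual scatter.

Compound 3 `Nc1nc(=O)n([C@H]2C=C[C@@H](CO)O2)cc1I` has not yet been measured. It keeps the core of compound 2 and differs in one place: iodo in place of bromo on an aromatic carbon. This is iodo in place of bromo on an aromatic carbon, ortho to an amino group.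

Within the data shown here, no measured pair differs in one place only, so the data give no direct size for a step of this kind. With one halogen exchanged for another and nothing else altered, no step beyond the scatter is expected in this assay, in either direction. That expectation starts from compound 2 at 91600 nM. The expected step is a 1.1-fold lower number from compound 2 to compound 3 (0.06 log units; within the scatter). For compound 3 the estimated value is 80000 nM, with an expected range from 30000 nM to 180000 nM.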

Compound 3, half-maximal inhibitory concentration: 98300 nM
For compound 3 the middle estimate is 1.2-fold (0.09 log units) below the measured one; the measured number falls inside the stated range.
By their numbers in this assay, from the lowest: compound 1; then compounds 2 and 3 (each within the scatter of the next).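

In this assay, within the data shown here, iodo in place of bromo on the aromatic carbon ortho to an amino group gives a 1.1-fold higher number from compound 2 to compound 3 (0.03 log units; within the scatter), the first step that differs in one place only. On this read-out, bromo and iodo at this position therefore cannot be told apart, which is a direct reading that the earlier pair of compounds could not supply. No accompanying measurement bears on this result, so it stands as an observation without an explanation.

Open, from the compounds shown here alone, is how far this holds for other groups on the same carbon: chloro, methyl or ethynyl could show whether the insensitivity extends beyond bromo and iodo, or is confined to these two halogens. Also open, going by these compounds, is how much the amino group ortho to this carbon contributes, since compound 1 differs from compound 2 in more than one place and its value therefore cannot be used to isolate the effect of either the halogen or the amino group.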